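Chloro for methoxy on the aryl piperazine arm

The compounds below may be only part of what the source reports. "The series", "measured", "known", "first", "only" and "open" are said of these compounds alone.

Compound 1 `COc1ccccc1N1CCN(CC(=O)N2CCN(c3nnc(-c4ccccc4)c(-c4ccccc4)n3)CC2)CC1` and compound 2 `O=C(CN1CCN(c2ccccc2Cl)CC1)N1CCN(c2nnc(-c3ccccc3)c(-c3ccccc3)n2)CC1` share one core; compound 3 `COc1ccc(-c2nnc(N3CCN(C(=O)CN4CCN(c5ccc(OC)cc5)CC4)CC3)nc2-c2ccc(OC)cc2)cc1` and compound 4 `COc1ccc(-c2nnc(N3CCN(C(=O)CN4CCN(c5ccc(Cl)cc5)CC4)CC3)nc2-c2ccc(OC)cc2)cc1` share another, and the difference between the two cores is not broken down here. In a functional assay on MCF7 cells (Homo sapiens) for cytotoxicity, read by MTT assay, with a stated time of 24 h (on this read-out higher numbers stand for weaker inhibition and lower numbers for stronger inhibition), compound 1 gives 167000 nM. Compound 2 gives 263000 nM in this assay. a 1.6-fold higher number from compound 1 to compound 2 (0.20 log units; within the scatter), the change being (chloro in place of methoxy on an aromatic carbon). For compound 3 this assay reports only a limit, > 821000 nM, which is the limit of > 821000 nM in this assay, at which 1 of the 3 values shown sits. Compound 4 carries the same kind of change, (chloro in place of methoxy on an aromatic carbon), though here the place is para to a large group rather than ortho to a large group. Resting on a 1.6-fold higher number from compound 1 to compound 2 (0.20 log units; within the scatter), the expected step is a step that the limit leaves unreadable from compound 3 to compound 4. The estimate for compound 4 in this assay is 900000 nM, and a limit rather than a number is again thought likely.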

Compound 4, half-maximal inhibitory concentration: 607000 nM
Beside the measured number, compound 4's estimate is 1.5-fold (0.17 log units) above it, within the range that was stated.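

On the second core, in this assay, chloro in place of methoxy gives an at least 1.3-fold lower number from compound 3 to compound 4 (0.13 log units; that floor lies within the scatter). Set beside the earlier step, this neither confirms nor rules out that the change carries over from one core to the other: the same change on two cores in this assay, a 1.6-fold higher number (0.20 log units; within the scatter) from compound 1 to compound 2 and an at least 1.3-fold lower number (0.13 log units; that floor lies within the scatter) from compound 3 to compound 4; the limit leaves it open whether they differ. The step rests on a limit for compound 3, so only a floor can be read, and in this pair the change also sits para to a large group, a further difference from the earlier pair: the limit of > 821000 nM in this assay, at which 1 of the 4 values shown sits.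

A number for compound 3 in place of its limit would be needed to fix the size of the step. Also open, from the compounds shown here alone, is how an amine or a carboxylic acid at the same place would read on either core.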